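Cyclohexyl amide follows a morpholine urea at a limit

The source may report more compounds than this note shows. Statements on the series, on what has been measured and on what is new or still open speak of the compounds shown alone.

Compound 1 `O=C(c1cccc(F)c1)N1CC(c2nc(-c3cccc(Cl)c3)no2)C1` gives > 10000 nM in an assay on HEK293 cells for positive allosteric modulation of metabotropic glutamate receptor 5 (Homo sapiens), read by FLIPR; on this read-out lower numbers stand for an effect already at smaller amounts and higher numbers for an effect only at larger amounts of compound. Compound 2 `O=C([C@H]1CC2CCC1C2)N1CC(c2nc(-c3cccc(Cl)c3)no2)C1` gives 74 nM. Compound 3 `CC1CN(C(=O)N2CC(c3nc(-c4cccc(Cl)c4)no3)C2)CC(C)O1` gives > 10000 nM.

Compound 3 stands only at a limit of this assay, not at a number; it shares that position with one other compound (the limit of > 10000 nM in this assay, at which 2 of the 3 values shown sit). Its value is among the highest shown, while compound 2 alone gives a number.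

Compound 4 `CC1CCCC(C(=O)N2CC(c3nc(-c4cccc(Cl)c4)no3)C2)C1` differs from compound 3 in one place: 3-methylcyclohexyl in place of 2,6-dimethylmorpholin-4-yl on a carbonyl carbon. The change concerns the group on the carbonyl carbon, the same place in which the measured steps differ. For the measured compounds named here, the step of an at least 130-fold higher number from compound 2 to compound 3 (2.13 log units; beyond the scatter) shows how far the dimethylmorpholinyl urea lies from the bicyclic carbocyclic amide, while a step that the two limits leave unreadable from compound 1 to compound 3 and an at least 130-fold lower number from compound 1 to compound 2 (2.13 log units; beyond the scatter) show that the carbocyclic ring gave the only number among the three. Compound 4 carries a carbocyclic ring on the carbonyl carbon, and so the step of an at least 66-fold lower number from compound 3 to compound 4 (1.82 log units; beyond the scatter) is expected to be large and downward, in the direction of compound 2. For compound 4 the value is estimated at 150 nM, between 40 nM and 1500 nM.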

Compound 4, half-maximal effective concentration: 410 nM
Compound 4: the middle estimate sits 2.7-fold (0.44 log units) below what was measured, within the range that was stated.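

In this assay, a single six-membered non-aromatic ring of carbon only on the carbonyl carbon also gives a number, so this is not confined to the two five-membered rings of compound 2: the change brings an at least 24-fold lower number from compound 3 to compound 4 (1.38 log units; beyond the scatter) and an at least 24-fold lower number from compound 1 to compound 4 (1.38 log units; beyond the scatter). The two carbon-only groups still differ, with a 5.5-fold higher number from compound 2 to compound 4 (0.74 log units; beyond the scatter). Compound 1 and compound 3 remain limits, not numbers: the limit of > 10000 nM in this assay, at which 2 of the 4 values shown sit.

Since 3-methylcyclohexyl differs from 2,6-dimethylmorpholin-4-yl in both its nitrogen and its oxygen, the compounds shown leave open which of these atoms accounts for the step, and a piperidin-1-yl group or a tetrahydropyran-4-yl group on the carbonyl carbon would separate them. Also open is what the methyl contributes, as plain cyclohexyl does not appear among these compounds.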